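Growing the amine side chain of compound 2 with a cyclohexyl ring

This account rests on a few compounds, and the source may have more. Where it says the series, first, only, none or still open, it means among the compounds named here.

Of the compounds shown here, three sharing one core have been measured in an assay on cells for inhibition of interleukin-5 receptor subunit alpha (Mus musculus), read by WST assay, with a stated time of 48 h, in the presence of a further agent that is not named here; a higher number here means a weaker inhibitor, a lower number a stronger inhibitor. Compound 1 `OCCCCNCc1nc2c(OCC3CCCCC3)cccc2[nH]1` gives 30000 nM, compound 2 `CCC(CO)NCc1nc2c(OCC3CCCCC3)cccc2[nH]1` gives 3500 nM, and compound 3 `CC(C)(CO)NCc1nc2c(OCC3CCCCC3)cccc2[nH]1` gives 27500 nM. Compound 2 stands lowest of the three, with an 8.6-fold lower number from compound 1 to compound 2 (0.93 log units; beyond the scatter) and a 7.9-fold higher number from compound 2 to compound 3 (0.90 log units; beyond the scatter). Compound 4 `OCC(CC1CCCCC1)NCc1nc2c(OCC3CCCCC3)cccc2[nH]1` is not yet measured; it differs from compound 2 by cyclohexyl in place of methyl on a saturated chain carbon, two bonds along the chain from an amine nitrogen. Both measured steps changed the group on the amine nitrogen and each moved this assay by a modest amount, so a change of similar size is plausible here, although neither step tests a cyclohexyl. The number for compound 4 is expected to be near 2000 nM, within 500 nM to 10000 nM, which would be a step of a 1.8-fold lower number from compound 2 to compound 4 (0.24 log units; within the scatter).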

Compound 4, half-maximal inhibitory concentration: 5000 nM
Compound 4: the middle estimate sits 2.5-fold (0.40 log units) below what was measured, within the range that was stated.
By their numbers in this assay, from the lowest: compounds 2 and 4 (each within the scatter of the next); then compounds 3 and 1 (each within the scatter of the next).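

The step to a cyclohexyl gives a 1.4-fold higher number from compound 2 to compound 4 (0.15 log units; within the scatter), so at this saturated chain carbon, two bonds along the chain from an amine nitrogen, six heavy atoms in a ring can replace the single carbon of methyl without a change that stands clear of the scatter. Going by these compounds alone, none of the earlier compounds carried a ring on this side chain. No supporting data are available to explain this result.

Going by these compounds, whether a phenyl ring would give a similar number at this position stays open. So does the effect of placing an amine or a carboxylic acid on the cyclohexyl ring.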